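Swapping a chlorophenyl for a nitrophenyl on the shared core

A few compounds are considered here, and "the series" means these few. Any claim that something is new, unique, unknown or untested is made for them only; others in the source may bear on it.

Compound 1 `CCCSc1nc(N/N=C/c2cccc(Cl)c2)c2nnn(Cc3ccccc3)c2n1`: > 64000 nM
Compound 2 `CCCSc1nc(N/N=C(\C)c2ccccc2O)c2nnn(Cc3ccccc3)c2n1`: 11000 nM
Compound 3 `CCCSc1nc(N/N=C(\C)c2ccccc2)c2nnn(Cc3ccccc3)c2n1`: 32100 nM

Going by these compounds, in a functional assay on MCF7 cells (Homo sapiens) for antiproliferative activity, read by MTT assay, with a stated time of 72 h (a higher number here means a weaker inhibitor, a lower number a stronger inhibitor), compound 1 gives only a limit, > 64000 nM, so its true number is unknown. Compound 4 `CCCSc1nc(N/N=C/c2ccc([N+](=O)[O-])cc2)c2nnn(Cc3ccccc3)c2n1` differs from compound 1 by 4-nitrophenyl in place of 3-chlorophenyl on a carbon with a double bond to nitrogen. For the measured compounds named here, no measured step changes this part alone: the steps of an at least 5.8-fold lower number from compound 1 to compound 2 (0.76 log units; beyond the scatter) and an at least 1.9-fold lower number from compound 1 to compound 3 (0.29 log units; that floor lies within the scatter) each also add a methyl on the same carbon, and the step of a 2.9-fold higher number from compound 2 to compound 3 (0.47 log units; beyond the scatter) concerns a hydroxy. Compound 1 sits at the limit (the limit of > 64000 nM in this assay, at which 1 of the 3 values shown sits). The nitro change therefore cannot be placed with confidence, and compound 4 is expected to remain a weak inhibitor near that limit. Compound 4 is estimated at 50000 nM, between 15000 nM and 150000 nM. This corresponds to an expected step of an at least 1.2-fold lower number from compound 1 to compound 4 (0.10 log units; that floor lies within the scatter).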

Compound 4, half-maximal inhibitory concentration: 11000 nM
For compound 4 the middle estimate is 4.5-fold (0.66 log units) above the measured one, and the stated range ends above it.
By their numbers in this assay, from the lowest: compounds 2 and 4 (each within the scatter of the next); then compound 3. At a limit, above all of these: compound 1.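

Changing the aromatic group on the carbon with a double bond to nitrogen clearly moves the result in this assay: 4-nitrophenyl in place of 3-chlorophenyl gives an at least 5.8-fold lower number from compound 1 to compound 4 (0.76 log units; beyond the scatter). Unlike the earlier steps from compound 1, this one adds no methyl on that carbon, so the aromatic group alone can shift the number. The true size of the step stays unknown, since compound 1 gives only a limit: the limit of > 64000 nM in this assay, at which 1 of the 4 values shown sits.

The group and its place on the ring change together, so their contributions cannot be separated. Going by these compounds, how an amine or a carboxylic acid on that ring would compare also remains open.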